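Working notes: from 4-iodophenyl to 4-bromophenyl

The source may report more compounds than this note shows. Statements on the series, on what has been measured and on what is new or still open speak of the compounds shown alone.

Measured values in a functional assay on K562 cells (Homo sapiens) for cytotoxicity, read by MTT assay, with a stated time of 72 h; a lower number here means a stronger inhibitor, a higher number a weaker inhibitor
- Compound 1 `Cc1ccc(S(=O)(=O)n2cc(COC3=C/C(=N\c4ccccc4)c4ccccc4C3=O)nn2)cc1` gives 12200 nM
- Compound 2 `CC(=O)c1ccc(/N=C2\C=C(OCc3cn(S(=O)(=O)c4ccc(C)cc4)nn3)C(=O)c3ccccc32)cc1` gives 5520 nM
- Compound 3 `Cc1ccc(S(=O)(=O)n2cc(COC3=C/C(=N\c4ccc(I)cc4)c4ccccc4C3=O)nn2)cc1` gives 10800 nM

Compound 3, at 10800 nM in this assay, lies within the scatter of both other compounds, with a 1.1-fold lower number from compound 1 to compound 3 (0.05 log units; within the scatter) and a 2.0-fold higher number from compound 2 to compound 3 (0.29 log units; within the scatter) as its two steps. Compound 4 `Cc1ccc(S(=O)(=O)n2cc(COC3=C/C(=N\c4ccc(Br)cc4)c4ccccc4C3=O)nn2)cc1` has bromo in place of iodo on an aromatic carbon, para to a large group, so that 4-iodophenyl becomes 4-bromophenyl bromo in place of iodo on an aromatic carbon while the rest of the structure stays the same.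

For the measured compounds named here, no measured step exchanges one halogen for another at this place. The closest evidence is the step that brings in iodo, a 1.1-fold lower number from compound 1 to compound 3 (0.05 log units; within the scatter) and thus no separation from compound 1 with its hydrogen. Going by the values given here, the only step beyond the scatter, a 2.2-fold lower number from compound 1 to compound 2 (0.34 log units; beyond the scatter) in size, brings in acetyl and remains modest. On this basis, no step beyond the scatter is expected for bromo in place of iodo. The estimated change is a 1.0-fold higher number from compound 3 to compound 4 (0.01 log units; within the scatter) and is expected to stay small. Compound 4 is expected at 11000 nM in this assay, with an estimated range from 7000 nM to 17000 nM as the likely span.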

Compound 4, half-maximal inhibitory concentration: 5400 nM
The estimate for compound 4 lay 2.0-fold (0.31 log units) above the measured number, outside the stated range (below it).
By their numbers in this assay, from the lowest: compounds 4, 2, 3 and 1 (each within the scatter of the next, the first and the last beyond it).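

In this assay, for the compounds shown here, bromo in place of iodo on this aromatic carbon, para to a large group, gives the first step between two halogens at this place (a 2.0-fold lower number from compound 3 to compound 4 (0.30 log units; within the scatter)), and the two compounds remain unseparated. Bromo is also not separated from acetyl (a 1.0-fold lower number from compound 2 to compound 4 (0.01 log units; within the scatter)), but it does separate from hydrogen (a 2.3-fold lower number from compound 1 to compound 4 (0.35 log units; beyond the scatter)), whereas iodo does not (a 1.1-fold lower number from compound 1 to compound 3 (0.05 log units; within the scatter)), so compound 4 joins compound 2 as the second compound with a modest step beyond the scatter from compound 1, with compound 3 going against any simple reading across the halogens. No measurement is at hand that accounts for these numbers.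

On these data alone, it remains open whether chloro or fluoro at this place would fall with bromo, with iodo or apart from both, and so whether the difference between compound 3 and compound 4 is more than scatter. As far as these compounds go, it is also open whether an amine, a carboxylic acid or a longer chain on this aromatic carbon would give a step from compound 1 larger than the modest ones seen so far.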